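Ethyl Ester of Compound 3 in the Stability Assay

The source may hold more compounds than are shown below. What is called first, only, known or untested is meant among the compounds shown, and "the series" means these compounds.

Measured compounds:
compound 1 `CCOC(=O)C1=C(S[C@@H]2CN[C@H](C(=O)Nc3cccc(C(=O)OCC)c3)C2)[C@H](C)[C@@H]2[C@@H]([C@@H](C)OC(=O)CC)C(=O)N12`: > 95%
compound 2 `C[C@@H](O)[C@H]1C(=O)N2C(C(=O)O)=C(S[C@@H]3CN[C@H](C(=O)Nc4cccc(C(=O)OCC(F)(F)F)c4)C3)[C@H](C)[C@H]12`: > 95%
compound 3 `CCOC(=O)c1cccc(NC(=O)[C@@H]2C[C@H](SC3=C(C(=O)O)N4C(=O)[C@H]([C@@H](C)O)[C@H]4[C@H]3C)CN2)c1`: > 95%

In an ADME assay for metabolic stability, read by LC-MS, with a stated time of 3 h, at pH 6.5, tested at 50 uM (on this read-out higher numbers stand for a more stable compound and lower numbers for a less stable compound), compound 1 reaches > 95%, which is a limit of the assay and not a number. Compound 2 likewise reports > 95%, again a limit. Compound 3 also sits at a limit, > 95%. So compound 3 stands where every value shown stands (the limit of > 95% in this assay, at which 3 of the 3 values shown sit). Among the measured compounds shown here, the single step among measured compounds, a step that the two limits leave unreadable from compound 2 to compound 3, is unreadable. Compound 4 `CCOC(=O)C1=C(S[C@@H]2CN[C@H](C(=O)Nc3cccc(C(=O)OCC)c3)C2)[C@H](C)[C@@H]2[C@@H]([C@@H](C)O)C(=O)N12` differs from compound 3 by ethyl in place of hydrogen on an oxygen next to a carbonyl group. For the measured compounds named here, no measured step bears on this change, so no size can be read from the data. Compound 1 carries ethoxycarbonyl rather than carboxy, and its result is also only a limit. Compound 4 is therefore expected to stay at the limit, with an estimated 96% between 85% and 100%, a step that the limit leaves unreadable from compound 3 to compound 4.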

Compound 4, percent of the compound remaining: > 95%
Compound 4: a limit, no number; the forecaster's own chance of this, stated with the estimate: 85%; the middle value lies beyond the limit too.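

No new step can be read between compound 4 and either compound 1 or compound 3 in this assay, as all three results are limits and not numbers: the limit of > 95% in this assay, at which 4 of the 4 values shown sit.

The compounds shown leave open whether any of these changes alters the percent of compound remaining at all.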